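This account rests on a few compounds, and the source may have more. Where it says the series, first, only, none or still open, it means among the compounds named here.

Compound 1 `COc1ccc(C(=O)/C=C/c2cc(OC)c(OC)c(OC)c2)c2c1C=CC(C)(C)O2` gives > 10000 nM in a functional assay on HT-29 cells (Homo sapiens) for antiproliferative activity, read by MTT assay, with a stated time of 24 h (on this read-out lower numbers stand for stronger inhibition and higher numbers for weaker inhibition), a limit of the assay and not a number.
Compound 2 `COc1ccc(C(=O)/C=C/c2ccc(N(C)C)cc2)c2c1C=CC(C)(C)O2` gives 1870 nM in this assay.
Compound 3 `COc1ccc(C(=O)/C=C/c2ccc([N+](=O)[O-])cc2)c2c1C=CC(C)(C)O2` gives 3730 nM in this assay.

Of the three measured compounds, compound 1 is the one for which only a limit is known; it sits at the limit of > 10000 nM in this assay, at which 1 of the 3 values shown sits, so where it stands relative to compound 2 and compound 3 cannot be placed in numbers. Compound 4 `COc1cc(/C=C/C(=O)c2ccc(OC)c3c2OC(C)(C)C=C3)cc(OC)c1O` differs from compound 1 in a single place: hydrogen in place of methyl on an oxygen on an aromatic ring, that is, methoxy to hydroxy on the shared core.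

For the measured compounds named here, the only measured step, a 2.0-fold higher number from compound 2 to compound 3 (0.30 log units; within the scatter), concerns a different change, nitro in place of dimethylamino on an aromatic carbon, and it stays within the scatter. Going by the values given here, no measured step speaks to the methoxy-to-hydroxy change itself, and compound 1 offers only a limit to start from. The expectation for compound 4 therefore rests on compound 1 alone: it is expected to stay near or beyond the same limit, with the step that the limit leaves unreadable from compound 1 to compound 4 meaning no clear movement.

The estimate for compound 4 in this assay is 15000 nM, expected to fall between 4000 nM and 60000 nM, with a real chance that only a limit is reported.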

Compound 4, half-maximal inhibitory concentration: > 10000 nM
Compound 4: no number, only a limit (the forecaster's own chance of this, stated with the estimate: 60%); the middle value lies beyond the limit too.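

In this assay compound 4, like compound 1, gives only a limit of the assay and not a number, so no step can be read for the change from methoxy to hydroxy: the limit of > 10000 nM in this assay, at which 2 of the 4 values shown sit.
The compounds shown leave open how far past that limit each of the two lies, and whether this change moves the value at all.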